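Replacing Fluoro with 4-Methylpiperazin-1-yl in Compound 3

The source may hold more compounds than are shown below. What is called first, only, known or untested is meant among the compounds shown, and "the series" means these compounds.

In a functional assay on NCI-H3255 cells (Homo sapiens) for antiproliferative activity, read by MTT assay, with a stated time of 72 h (a lower number here means a stronger inhibitor, a higher number a weaker inhibitor), compound 1 (`O=C(Nc1cc(Nc2ccc(Cl)cc2)ncn1)c1ccc(F)cc1`) gives > 30000 nM as its reading, which is a limit of the assay and not a number. Compound 2 (`COc1ccc(OC)c(Nc2cc(Nc3ccc(F)cc3)ncn2)c1`) gives > 30000 nM as its reading, again only a limit. Compound 2 therefore stands at a limit, with no exact number to build on. Compound 3 (`COc1ccc(OC)c(Nc2cc(Nc3ccc(N4CCN(C)CC4)cc3)ncn2)c1`) carries 4-methylpiperazin-1-yl in place of fluoro on an aromatic carbon. For the measured compounds named here, no measured pair of compounds shows what such a change does, so the expectation here is a judgement resting on the structural change alone. The expected change in this assay is an at least 10-fold lower number from compound 2 to compound 3 (1.00 log units; beyond the scatter) toward a lower number and stronger inhibition, a step clearly beyond the usual scatter. The estimate for compound 3 is 3000 nM with an expected range from 300 nM to 30000 nM as its bounds.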

Compound 3, half-maximal inhibitory concentration: > 30000 nM
Compound 3 gave a limit, no number; the forecaster's own chance of this, stated with the estimate: 25%; middle value at least 10-fold (1.00 log units) away from the limit.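

Compound 2 and compound 3 both read only as limits in this assay, so no step between them can be read, and the reading stops at one shared ceiling: the limit of > 30000 nM in this assay, at which 3 of the 3 values shown sit.

The compounds shown leave open how strongly any of them inhibits, and whether 4-methylpiperazin-1-yl in place of fluoro changes that at all.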